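The source may hold more compounds than are shown below. What is called first, only, known or untested is meant among the compounds shown, and "the series" means these compounds.

Among the compounds with values here, compound 3 `Cc1ccc2oc(SCC(=O)Nc3ccc(-c4nc(-c5ccccc5)c(-c5ccccc5)n4C)cc3)nc2c1` gives 69.8% in a functional assay on HT-29 cells (Homo sapiens) for cytotoxicity, read by MTT assay, with a stated time of 24 h, tested at 80 ug/mL (a lower number here means a weaker effect, a higher number a stronger effect of the compound at the concentration tested), the lowest of the three numbers measured so far. Its nearest neighbour is compound 1 `Cn1c(-c2ccc(NC(=O)CCl)cc2)nc(-c2ccccc2)c1-c1ccccc1`, which gives 76.1% in this assay; the step of a number 6.3 percentage points lower from compound 1 to compound 3 (within the scatter) stays within the scatter. Furthest away is compound 2 `Cn1c(-c2ccc(NC(=O)CSc3nc4ccccc4o3)cc2)nc(-c2ccccc2)c1-c1ccccc1`, which gives 81.5% in this assay; the step of a number 11.7 percentage points lower from compound 2 to compound 3 (beyond the scatter) is the only one beyond the scatter. Compound 4 `Cn1c(-c2ccc(NC(=O)CSc3nc4ccccc4s3)cc2)nc(-c2ccccc2)c1-c1ccccc1` has not yet been measured in this assay. 1,3-benzothiazol-2-yl in place of 5-methyl-1,3-benzoxazol-2-yl on a sulfur The change sits on a sulfur whose other neighbour is a saturated chain carbon. Within the data shown here, two measured steps bear on it: the step of a number 11.7 percentage points lower from compound 2 to compound 3 (beyond the scatter) shows that hydrogen in place of methyl on that aromatic carbon alone would raise the number modestly, and the step of a number 5.4 percentage points higher from compound 1 to compound 2 (within the scatter) shows that (1,3-benzoxazol-2-yl)sulfanyl in place of chloro changed little. Among the measured compounds shown here, no measured pair covers a 1,3-benzothiazol-2-yl against a 1,3-benzoxazol-2-yl, so compound 4 is expected to land near compound 2. The step of a number 8.2 percentage points higher from compound 3 to compound 4 (within the scatter) is therefore expected to be upward. Compound 4 is estimated at 78%, with a range from 66% to 88%.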

Compound 4, a percentage reported as activity, at one concentration (the size of the read-out at that concentration, not a potency): 82.7%
Estimate against measurement, compound 4: 4.7 percentage points below, within the range that was stated.
By their numbers in this assay, from the lowest: compounds 3, 1, 2 and 4 (each within the scatter of the next, the first and the last beyond it).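

On the sulfur, the exchange of 1,3-benzoxazol-2-yl for 1,3-benzothiazol-2-yl in this assay gives a number 1.2 percentage points higher from compound 2 to compound 4 (within the scatter) and so does not separate the two groups. The result with the larger gap, a number 12.9 percentage points higher from compound 3 to compound 4 (beyond the scatter) and beyond what separates the other pairs, is about the size of the step the methyl gave on its own, which leaves compound 3 set apart from compound 2 and compound 4 but not from compound 1. The chloro group also stays unseparated from this new group, with a number 6.6 percentage points higher from compound 1 to compound 4 (within the scatter) as its step. No measurement at hand explains these differences. From the compounds shown here alone, whether a 5-methyl-1,3-benzothiazol-2-yl would repeat the methyl step remains open, as does how an amine such as morpholin-4-yl would read in place of the sulfanyl group on the saturated chain carbon.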